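Removing One Methoxy Group: An Expected Small Step

This account rests on a few compounds, and the source may have more. Where it says the series, first, only, none or still open, it means among the compounds named here.

Measured compounds:
compound 1 `COc1ccc(-c2cc(/C=C/C(=O)c3ccc(N)cc3)[nH]n2)cc1`: 3360 nM
compound 2 `COc1cc(-c2cc(/C=C/C(=O)c3ccc(N)cc3)[nH]n2)cc(OC)c1OC`: 3630 nM
compound 3 `COc1ccc(C(=O)/C=C/c2cc(-c3cc(OC)c(OC)c(OC)c3)n[nH]2)cc1OC`: 3780 nM

All three have been tested in a functional assay on HCC 2998 cells (Homo sapiens) for inhibition, read by sulforhodamine B assay, with a stated time of 48 h; a lower number here means a stronger inhibitor of growth, a higher number a weaker inhibitor of growth. Compound 2 stands second highest of the three numbers, yet its nearest and furthest neighbours, compound 3 and compound 1, both lie within the scatter of it, so none of the three can be called a stronger or weaker inhibitor than the others. For the measured compounds named here, the only single-point step available, a 1.0-fold higher number from compound 2 to compound 3 (0.02 log units; within the scatter), concerns the aryl group on the carbonyl carbon and shows that exchanging it produced nothing beyond the scatter.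

Compound 4 `COc1ccc(-c2cc(/C=C/C(=O)c3ccc(N)cc3)[nH]n2)cc1OC` differs from compound 2 elsewhere: hydrogen in place of methoxy on an aromatic carbon. Going by the values given here, no measured step covers this exact change. Compound 1 carries a single methoxy on that ring and shows a number within the scatter of compound 2, but it differs from compound 2 in two places, so the two values can only be set side by side. Among the compounds with values here, nothing measured so far points to a step beyond the scatter here. Compound 4 is therefore expected to give 3500 nM (range 1500 nM to 8000 nM), an estimated step of a 1.0-fold lower number from compound 2 to compound 4 (0.02 log units; within the scatter).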

Compound 4, concentration for total growth inhibition: 3830 nM
Beside the measured number, compound 4's estimate is 1.1-fold (0.04 log units) below it; measured number inside the range.
By their numbers in this assay, from the lowest: compounds 1, 2, 3 and 4 (each within the scatter of the next).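

In this assay the exchange at this position gives a 1.1-fold higher number from compound 2 to compound 4 (0.02 log units; within the scatter) and a second exchange on the same ring, methoxy in place of hydrogen, gives a 1.1-fold higher number from compound 1 to compound 4 (0.06 log units; within the scatter) to complete the link. Compound 1 and compound 2 differ in two places and could only be set side by side, but compound 4 now joins each of them by a single change, and both changes stay within the scatter. No outside evidence bears on this result, so the numbers stand without an explanation.

Going by these compounds, what a hydroxy group or a longer chain such as ethoxy would do on this carbon remains open. Also open, on these data alone, is whether the same exchange of hydrogen for methoxy would read alike with 3,4-dimethoxyphenyl on the carbonyl carbon in place of 4-aminophenyl.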